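From Methyl to Methoxycarbonyl in a Cytotoxicity Series

The source may report more compounds than this note shows. Statements on the series, on what has been measured and on what is new or still open speak of the compounds shown alone.

Measured in a functional assay on NCI-H460 cells (Homo sapiens) for cytotoxicity, read by MTT assay, with a stated time of 68 h; a lower number here means a stronger inhibitor, a higher number a weaker inhibitor:
- compound 1 `Nc1cccc(-c2cccc(NC(=O)C(Cl)Cl)c2)c1`: > 50000 nM, a limit
- compound 2 `O=C(Nc1cccc(-c2cccc(F)c2)c1)C(Cl)Cl`: > 50000 nM, a limit
- compound 3 `Cc1ccc(-c2cccc(NC(=O)C(Cl)Cl)c2)cc1`: 8000 nM

Among the measured compounds shown here, compound 3 holds the only actual number of the three. The other two entries give no number, only (the limit of > 50000 nM in this assay, at which 2 of the 3 values shown sit).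

Compound 4 `COC(=O)c1ccc(-c2cccc(NC(=O)C(Cl)Cl)c2)cc1` carries methoxycarbonyl in place of methyl on an aromatic carbon, para to a large group: methoxycarbonyl in place of methyl on an aromatic carbon.

For the measured compounds named here, only one measured step connects compounds that differ in one place: a step that the two limits leave unreadable from compound 1 to compound 2. Going by the values given here, it has no readable size, so it offers nothing to carry over, and no measured step involves the methyl of compound 3. The expectation therefore rests on thin ground. Among the compounds with values here, with compound 3 at 8000 nM as the sole number, and the rest of the set at the limit of > 50000 nM in this assay, at which 2 of the 3 values shown sit, a moderate weakening in this assay is expected rather than a gain. The expected change is a 1.9-fold higher number from compound 3 to compound 4 (0.27 log units; within the scatter). For compound 4 the estimate is 15000 nM, with an expected range of 4000 nM to 50000 nM.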

Compound 4, half-maximal inhibitory concentration: > 50000 nM
Compound 4 ended at the assay's limit (the forecaster's own chance of this, stated with the estimate: 30%); at least 3.3-fold (0.52 log units) between middle value and limit.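

In this assay, among the compounds shown here, methoxycarbonyl in place of methyl on this aromatic carbon, para to a large group, gives an at least 6.2-fold higher number from compound 3 to compound 4 (0.79 log units; beyond the scatter), the first step in the set with a readable size and one that lies beyond the scatter. Compound 4 gives > 50000 nM, which is a limit of the assay and not a number. This position therefore responds to the group it carries, and compound 3 remains the only compound of the four with an actual number: the limit of > 50000 nM in this assay, at which 3 of the 4 values shown sit.

Going by these compounds, the true value of compound 4 stays unknown, and the step from compound 1 to compound 2 cannot be read. On these data alone, whether an ethyl, a methoxy or a carboxylic acid on the same aromatic carbon would stay near compound 3 or fall to the same limit remains open.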